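The source may hold more compounds than are shown below. What is called first, only, known or untested is meant among the compounds shown, and "the series" means these compounds.

Measured compounds:
compound 1 `NCCNc1c(C(=O)NCc2ccc(F)cc2)nc(Br)c2cccnc12` — > 20000 nM
compound 2 `O=C(NCc1ccc(F)cc1)c1nc(NCCO)c2cccnc2c1O` — "not determined" (no result reported)

In a functional assay on HCT-116 cells (Homo sapiens) for cytotoxicity, read by MTT assay, with a stated time of 72 h (on this read-out lower numbers stand for stronger inhibition and higher numbers for weaker inhibition), compound 1 gives only a limit, > 20000 nM, so it stands at the limit of > 20000 nM in this assay, at which 1 of the 2 values shown sits. Compound 2 `O=C(NCc1ccc(F)cc1)c1nc(NCCO)c2cccnc2c1O` gives "not determined" (no result reported) in this assay, so it offers no number to compare. Compound 3 `NCCCNc1c(C(=O)NCc2ccc(F)cc2)nc(Br)c2cccnc12` differs from compound 1 by aminomethyl in place of amino on a saturated chain carbon, two bonds along the chain from a nitrogen on an aromatic ring. For the measured compounds named here, no step between measured compounds is available, so only a shift within the usual scatter is expected in this assay, in no set direction. Compound 3 is therefore expected to give 30000 nM, within 10000 nM to 100000 nM. The expected step is a step that the limit leaves unreadable from compound 1 to compound 3.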

Compound 3, half-maximal inhibitory concentration: > 20000 nM
Compound 3 was reported as a limit; the forecaster's own chance of this, stated with the estimate: 75%; the middle value does not contradict the limit.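

For the compounds shown here, compound 1 and compound 3 each give a limit rather than a number, so no step between them can be read: the limit of > 20000 nM in this assay, at which 2 of the 3 values shown sit. As far as these compounds go, how the (2-aminoethyl)amino and (3-aminopropyl)amino groups compare in strength remains open.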